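The source may report more compounds than this note shows. Statements on the series, on what has been measured and on what is new or still open speak of the compounds shown alone.

Compound 1 `CCOc1ccc(F)cc1C(C)NC(=O)NS(=O)(=O)c1ccccc1` gives > 300000 nM.
Compound 2 `CCOc1ccc(F)cc1C(C)NC(=O)NS(=O)(=O)c1ccc(C)cc1` gives > 300000 nM.
Compound 3 `COc1ccc(F)cc1C(C)NC(=O)NS(=O)(=O)c1ccccc1` gives > 300000 nM.

Each of these three values is a limit of a functional assay on thoracic aorta (Rattus norvegicus, strain Wistar), with a stated time of 15 min (a higher number here means that more compound is needed for the effect, a lower number that less compound is needed), rather than a number. Compound 1 stands at that limit. The two compounds shown beside it stand at the same limit, as the limit of > 300000 nM in this assay, at which 3 of the 3 values shown sit, records. The step from compound 1 to compound 2, a step that the two limits leave unreadable from compound 1 to compound 2, is methyl in place of hydrogen on an aromatic carbon. The step from compound 1 to compound 3, a step that the two limits leave unreadable from compound 1 to compound 3, is hydrogen in place of methyl on a saturated chain carbon bound to an oxygen on an aromatic ring. Neither step has a readable size. Compound 4 `CCOc1ccc(Cl)cc1C(C)NC(=O)NS(=O)(=O)c1ccccc1` differs from compound 1 by chloro in place of fluoro on an aromatic carbon, on an aromatic carbon of a six-membered aromatic ring of carbon only, meta to a large group and para to an ethoxy group. Among the compounds with values here, no measured step bears directly on this exchange, and every value so far sits at the limit. Compound 4 is therefore expected to remain near that limit, the step from compound 1 being estimated as a number no higher from compound 1 to compound 4 (the limit leaves the size open). The estimate for compound 4 is 300000 nM, within 100000 nM to 1000000 nM.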

Compound 4, half-maximal effective concentration: > 300000 nM
Compound 4 was reported as a limit; the forecaster's own chance of this, stated with the estimate: 85%; the middle value lies on the limit itself.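

In this assay compound 4 gives > 300000 nM, which is a limit and not a number, so no step can be read between compound 1 and compound 4. The compounds shown leave open whether any of these exchanges alters the response at all, since all of them stand at one limit: the limit of > 300000 nM in this assay, at which 4 of the 4 values shown sit.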